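A ring swap at compound 2

The compounds below may be only part of what the source reports. "The series", "measured", "known", "first", "only" and "open" are said of these compounds alone.

Measured in a functional assay on DU-145 cells (Homo sapiens) for inhibition, read by trypan blue exclusion, with a stated time of 96 h (a lower number here means a stronger inhibitor of growth, a higher number a weaker inhibitor of growth), so far:
- compound 1 `Cc1ccc(/C=C(\C(=O)c2ccc(Cl)cc2)S(=O)(=O)Cc2ccc(F)cc2)s1` gives 50000 nM
- compound 2 `CCOc1ccc(/C=C(\C(=O)c2ccc(Cl)cc2)S(=O)(=O)Cc2ccc(F)cc2)cc1OC` gives 50000 nM

Going by the values given here, compound 2 stands level with compound 1, the only other compound measured. Compound 3 `Cc1ccsc1/C=C(\C(=O)c1ccc(Cl)cc1)S(=O)(=O)Cc1ccc(F)cc1` has not been measured yet. It differs from compound 2 at one place, on a double-bonded chain carbon bound to a double-bonded chain carbon, where 3-methylthiophen-2-yl replaces 4-ethoxy-3-methoxyphenyl: 3-methylthiophen-2-yl in place of 4-ethoxy-3-methoxyphenyl on a double-bonded chain carbon bound to a double-bonded chain carbon is the whole difference. Among the compounds with values here, the one measured step at this place gave no change at the digits printed from compound 1 to compound 2 (within the scatter) and offers no sign of a large shift, though a single step is thin evidence. The estimated step is no change at the digits printed from compound 2 to compound 3 (within the scatter) and nothing beyond the scatter is expected in this assay for this swap. For compound 3 the expected value is 50000 nM (estimated range 12000 nM to 100000 nM).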

Compound 3, concentration for 50% growth inhibition: 10000 nM
For compound 3 the middle estimate is 5.0-fold (0.70 log units) above the measured one; measured number below the stated range.
By their numbers in this assay, from the lowest: compound 3; then compounds 1 and 2 (each within the scatter of the next).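

In this assay, going by these compounds alone, this position proved able to respond: 3-methylthiophen-2-yl in place of 4-ethoxy-3-methoxyphenyl gives a 5.0-fold lower number from compound 2 to compound 3 (0.70 log units; beyond the scatter) and is the first step here beyond the scatter. The ring need not change in kind for this to happen, since 3-methylthiophen-2-yl in place of 5-methylthiophen-2-yl gives a 5.0-fold lower number from compound 1 to compound 3 (0.70 log units; beyond the scatter) as well. So the placing of the methyl on the thiophene ring matters in this series.

On these data alone, whether a bare thiophen-2-yl, or an amine or a carboxylic acid on this ring, would move the number further remains open. Nothing measured here explains the shift.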